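The source may report more compounds than this note shows. Statements on the series, on what has been measured and on what is new or still open speak of the compounds shown alone.

Of the compounds shown here, three built on one shared core have been measured in a functional assay, with a stated time of 20 min; a lower number here means a stronger inhibitor, a higher number a weaker inhibitor. Compound 1 `Cn1c(NN)nc(-c2cccc(O)c2O)c(C#N)c1=O` gives 34 ug/mL in this assay, and compound 2 `Cn1c(NN)nc(-c2ccc(Cl)cc2)c(C#N)c1=O` gives 44 ug/mL. Compound 3 `CSc1nc(-c2ccc(N(C)C)cc2)c(C#N)c(=O)n1C` gives 78 ug/mL, the highest of the three numbers; its gap to compound 2 lies within the usual scatter of repeated measurements, while its gap to compound 1 lies beyond it. Compound 4 `CN(C)c1ccc(-c2nc(NN)n(C)c(=O)c2C#N)cc1` has not yet been measured. It differs from compound 3 in a single place: aminoamino in place of methylsulfanyl on an aromatic carbon. Compound 1 and compound 2 already carry the aminoamino group that enters here; compound 1 sits clearly lower than compound 3, whereas compound 2 sits within the scatter of compound 3. Both also differ from compound 4 in another part of the structure, so no clean one-change comparison exists. The change is therefore expected to bring a modest move towards a lower number, as a 1.7-fold lower number from compound 3 to compound 4 (0.24 log units; within the scatter), with real uncertainty. Compound 4 is expected to give about 45 ug/mL in this assay, within a range from 20 ug/mL to 100 ug/mL.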

Compound 4, half-maximal inhibitory concentration: 81 ug/mL
For compound 4 the middle estimate is 1.8-fold (0.26 log units) below the measured one; low and high end bracket the measured number.
By their numbers in this assay, from the lowest: compounds 1, 2, 3 and 4 (each within the scatter of the next, the first and the last beyond it).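

In this assay, among the compounds shown here, the first clean one-change comparison at this position, aminoamino in place of methylsulfanyl gives a 1.0-fold higher number from compound 3 to compound 4 (0.02 log units; within the scatter) and so shows no measurable effect of this exchange on the aromatic carbon between two ring nitrogen atoms, at least with dimethylamino elsewhere in the molecule. With aminoamino held constant, dimethylamino in place of chloro gives a 1.8-fold higher number from compound 2 to compound 4 (0.27 log units; within the scatter) and also leaves the two compounds indistinguishable in this measurement. Nothing available explains why either exchange leaves the number unmoved.

From the compounds shown here alone, whether other groups at this position, such as a simple amine, a methoxy group or a longer alkyl chain, would also leave the number unmoved remains open. Going by these compounds, it is equally open whether aminoamino and methylsulfanyl would still match if chloro replaced dimethylamino.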